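Swapping a Chlorophenyl for a Cyclopropylmethyl: Stability Outlook

A few compounds are considered here, and "the series" means these few. Any claim that something is new, unique, unknown or untested is made for them only; others in the source may bear on it.

Compound 1, `CS(=O)(=O)Nc1ccc2c(c1)S(=O)(=O)N=C(C1=C(O)C3CCCC3N(Cc3ccc(Cl)cc3)C1=O)N2`, was tested in an in vitro ADME assay on microsomes from liver (Homo sapiens) for metabolic stability; on this read-out lower numbers stand for a shorter-lived compound and higher numbers for a longer-lived compound. In this assay compound 1 gives > 1 h, which is a limit of the assay rather than a number. Two relatives share its core. Compound 2, `CS(=O)(=O)Nc1ccc2c(c1)S(=O)(=O)N=C(C1=C(O)[C@H]3CCCC[C@H]3N(Cc3ccc(F)cc3)C1=O)N2`, gives > 1 h in this assay, again a limit. Compound 3, `CS(=O)(=O)Nc1ccc2c(c1)S(=O)(=O)N=C(C1=C(O)[C@H]3CCC[C@H]3N(CC3CC3)C1=O)N2`, gives > 1 h in this assay, also a limit. So compound 1 stands where every measured compound stands: at the limit of > 1 h in this assay, at which 3 of the 3 values shown sit, and no measured pair differing in a single place is available to show how large a single change moves this read-out.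

Compound 4, `CS(=O)(=O)Nc1ccc2c(c1)S(=O)(=O)N=C(C1=C(O)C3CCCC3N(CCC3CC3)C1=O)N2`, has not been measured. It differs from compound 1 by cyclopropylmethyl in place of 4-chlorophenyl on a saturated chain carbon bound to an amide-type nitrogen in a ring. Because the three measured values all sit at the limit of > 1 h in this assay, at which 3 of the 3 values shown sit, compound 4 is expected to stay at or near that limit, so the step that the limit leaves unreadable from compound 1 to compound 4 is estimated to lie within the usual scatter. The half-life of compound 4 in this assay is estimated at 1.2 h, within a range from 0.5 h to 3 h.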

Compound 4, half-life: 0.417 h
Compound 4: middle estimate off by 2.9-fold (0.46 log units), on the high side; measured number outside the range, below it.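

In this assay the change from 4-chlorophenyl to cyclopropylmethyl on a saturated chain carbon bound to an amide-type nitrogen in a ring gives an at least 2.3-fold lower number from compound 1 to compound 4 (0.37 log units; beyond the scatter) and so yields the first value shown that sits off the limit. Within the data shown here, this place can therefore move the half-life, a point the earlier compounds could not show since they shared one ceiling: the limit of > 1 h in this assay, at which 3 of the 4 values shown sit. Compound 1 gives > 1 h and that value is a limit of the assay.

On these data alone, the full size of the step remains open, as does whether losing the chlorine, losing the aromatic ring or changing to the cyclopropyl ring accounts for it. Also open, as far as these compounds go, is where a plain benzyl or a longer chain ending in an amine would fall at this place.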